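Compound 2 to compound 3: diethylamino gives way to pyrrolidine

The compounds below may be only part of what the source reports. "The series", "measured", "known", "first", "only" and "open" are said of these compounds alone.

In a functional assay on HepG2 cells (Homo sapiens) for antiproliferative activity, read by MTT assay, with a stated time of 48 h (a lower number here means a stronger inhibitor, a higher number a weaker inhibitor), compound 1 (`COc1cc2oc(-c3ccccc3)cc(=O)c2c(O)c1OCCCCN1CCCCC1`) gives 21000 nM and compound 2 (`CCN(CC)CCCOc1c(OC)cc2oc(-c3ccccc3)cc(=O)c2c1O`) gives 3700 nM. Among the measured compounds shown here, compound 2 therefore holds the lower of the two numbers so far. For the measured compounds named here, the only measured step is a 5.7-fold lower number from compound 1 to compound 2 (0.75 log units; beyond the scatter).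

Compound 3 (`COc1cc2oc(-c3ccccc3)cc(=O)c2c(O)c1OCCCCN1CCCC1`) is next, with (pyrrolidin-1-yl)methyl in place of diethylamino on a saturated chain carbon, three bonds along the chain from an oxygen on an aromatic ring.

The measured step bears on this change in reverse. It replaced (piperidin-1-yl)methyl with diethylamino on the same chain carbon, whereas the new change replaces diethylamino with a ring-bearing group of similar name. The ring is not the same one, and a single step is thin evidence. A move to a higher number in this assay is expected, of about the size of a 5.7-fold lower number from compound 1 to compound 2 (0.75 log units; beyond the scatter) or somewhat smaller. The expected change is a 3.2-fold higher number from compound 2 to compound 3 (0.51 log units; beyond the scatter). For compound 3 the estimated value is 12000 nM, with an expected range of 5000 nM to 30000 nM.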

Compound 3, half-maximal inhibitory concentration: 4900 nM
The estimate for compound 3 lay 2.4-fold (0.39 log units) above the measured number; measured number outside the range, below it.
By their numbers in this assay, from the lowest: compounds 2 and 3 (each within the scatter of the next); then compound 1.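

In this assay, the step to the pyrrolidine shows that replacing diethylamino with (pyrrolidin-1-yl)methyl on this saturated chain carbon leaves the number within the scatter: a 1.3-fold higher number from compound 2 to compound 3 (0.12 log units; within the scatter). Among the compounds shown here, the other new step, a 4.3-fold lower number from compound 1 to compound 3 (0.63 log units; beyond the scatter), is a comparison the earlier compounds did not offer: pyrrolidin-1-yl in place of piperidin-1-yl, read on a saturated chain carbon, four bonds along the chain from an oxygen on an aromatic ring, moves the number beyond the scatter. Having a ring on the nitrogen therefore does not by itself set compound 1 apart, since compound 3 also carries one and still cannot be told from compound 2, and no measurement in hand accounts for either step.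

Compound 2 and compound 3 differ in both the amine and the chain as printed, 3-(diethylamino)propyl against 4-(pyrrolidin-1-yl)butyl. A 4-(diethylamino)butyl or a 3-(pyrrolidin-1-yl)propyl group would be needed to separate the two contributions. Also open, on these data alone, is how a morpholine ring on the same butyl chain would compare with pyrrolidin-1-yl and piperidin-1-yl.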